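Swapping Methoxy for Chloro on a Thiourea Aryl Ring

The source may report more compounds than this note shows. Statements on the series, on what has been measured and on what is new or still open speak of the compounds shown alone.

Measured compounds in a functional assay on T98G cells (Homo sapiens) for inhibition, read by MTT assay, with a stated time of 72 h; on this read-out higher numbers stand for weaker inhibition and lower numbers for stronger inhibition:
compound 1 `COc1cccc(NC(=S)NC2CC(C)(C)Oc3ccc(Br)cc32)c1` gives 87000 nM;
compound 2 `CC1(C)CC(NC(=O)NCc2ccccc2)c2cc(Cl)ccc2O1` gives 15000 nM;
compound 3 `CC(C)NC(=O)NC1CC(C)(C)Oc2ccc(Cl)cc21` gives > 100000 nM, which is a limit of the assay rather than a number.

Of the two plain numbers, compound 1 stands highest, with compound 2 as its nearest neighbour at a lower number, beyond the scatter. Among the compounds with values here, the single measured step, an at least 6.6-fold higher number from compound 2 to compound 3 (0.82 log units; beyond the scatter), sits on an amide-type nitrogen of the shared core, and its size is bounded because the limit of > 100000 nM in this assay, at which 1 of the 3 values shown sits, applies there. Compound 4 `CC1(C)CC(NC(=S)Nc2cccc(Cl)c2)c2cc(Br)ccc2O1` differs from compound 1 elsewhere: chloro in place of methoxy on an aromatic carbon. Within the data shown here, no measured step touches this change, so for compound 4 a step in this assay within the scatter is expected, a 1.2-fold lower number from compound 1 to compound 4 (0.09 log units; within the scatter). Compound 4 is therefore estimated at 70000 nM, between 25000 nM and 200000 nM.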

Compound 4, half-maximal inhibitory concentration: 9000 nM
Beside the measured number, compound 4's estimate is 7.8-fold (0.89 log units) above it; the measured number lies below the stated range.
By their numbers in this assay, from the lowest: compounds 4 and 2 (each within the scatter of the next); then compound 1. At a limit, above all of these: compound 3.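

On this aromatic carbon the exchange matters: in this assay, chloro in place of methoxy gives a 9.7-fold lower number from compound 1 to compound 4 (0.99 log units; beyond the scatter) toward stronger inhibition. Within the data shown here, the earlier step showed a change only on an amide-type nitrogen, so this is the first sign that the group on the aryl ring also moves the number. Nothing measured here explains this step.

On these data alone, with only methoxy and chloro compared at this carbon, it remains open whether chloro itself is favourable or methoxy is simply unfavourable. A methyl group, a fluoro group or an amine at the same place could help separate these two readings.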